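Ethoxy to Isopropoxy on a Second Aryl Variant

The source may report more compounds than this note shows. Statements on the series, on what has been measured and on what is new or still open speak of the compounds shown alone.

Three compounds were measured in a functional assay on cells (T-cell, Homo sapiens) for inhibition; on this read-out lower numbers stand for stronger inhibition and higher numbers for weaker inhibition. Compound 1 `CCOc1nc(N)nc2ncc(-c3ccc(OC)cc3)nc12` gives only a limit of the assay, > 10000 nM. Compound 2 `COc1ccc(-c2cnc3nc(N)nc(OC(C)C)c3n2)cc1` likewise gives only a limit, > 10000 nM. Compound 3 `CCOc1nc(N)nc2ncc(-c3ccc(F)c(F)c3)nc12` also gives only a limit, > 10000 nM. Compound 2 differs from compound 1 by methyl in place of hydrogen on a saturated chain carbon bound to an oxygen on an aromatic ring and a saturated chain carbon; the result is a step that the two limits leave unreadable from compound 1 to compound 2, because of the limit of > 10000 nM in this assay, at which 3 of the 3 values shown sit. The difference between the cores of compound 1 and compound 3 is not broken down here. Compound 4 `CC(C)Oc1nc(N)nc2ncc(-c3ccc(F)c(F)c3)nc12` carries the same change relative to compound 3: methyl in place of hydrogen on a saturated chain carbon bound to an oxygen on an aromatic ring and a saturated chain carbon. The earlier step offers no size to lean on, and all three measured values sit at the limit, so a weak outcome is the natural expectation. Compound 4 is therefore expected at 15000 nM, within a range from 3000 nM to 60000 nM, and most likely reported only as a limit again. The step that the limit leaves unreadable from compound 3 to compound 4 is the expected one.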

Compound 4, half-maximal inhibitory concentration: 10000 nM
Estimate against measurement, compound 4: 1.5-fold (0.18 log units) above, and the stated range covers the measured number.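

In this assay, the change from ethoxy to isopropoxy on the core of compound 3 gives a number no higher from compound 3 to compound 4 (the limit leaves the size open). The same change on the core of compound 1 also has no readable size, so the two steps agree only in that neither shows a gain in inhibition that can be measured. The compounds do not show whether the change has the same size on both cores, because the values crowd at one edge of the assay: the limit of > 10000 nM in this assay, at which 3 of the 4 values shown sit.

As far as these compounds go, it remains open whether any group at this place brings inhibition clear of that limit. From the compounds shown here alone, what an amine or a longer chain in place of the isopropoxy would do also stays open.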